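Removing the Fluoro from Compound 1

The source may report more compounds than this note shows. Statements on the series, on what has been measured and on what is new or still open speak of the compounds shown alone.

Three close relatives built on one shared core have been tested in a functional assay on CHO cells for antagonist activity at adenosine receptor A2b (Homo sapiens), read by 33P incorporation, with a stated time of 20 min, in the presence of a further agent that is not named here; a lower number here means a stronger inhibitor, a higher number a weaker inhibitor. Compound 1 `Cn1cc2c(Cl)nc(NC(=O)c3ccc(F)cc3)nc2n1` returns only the assay's limit, > 20000 nM, not a number. Compound 2 `CCOC(=O)c1nc(NC(=O)c2ccc(C)cc2)nc2nn(CC(C)(C)C)cc12` also gives the limit, > 20000 nM. Compound 3 `CC(C)n1cc2c(Cl)nc(NC(=O)c3ccc(F)cc3)nc2n1` likewise gives the limit, > 20000 nM. For the measured compounds named here, the single one-place step among them, a step that the two limits leave unreadable from compound 1 to compound 3, therefore cannot be read. All three values rest at the limit of > 20000 nM in this assay, at which 3 of the 3 values shown sit. The untested compound 4 `Cn1cc2c(Cl)nc(NC(=O)c3ccccc3)nc2n1` differs from compound 1 by hydrogen in place of fluoro on an aromatic carbon. Going by the values given here, no measured step bears on this change, so nothing here points to a shift beyond the scatter. Compound 4 is expected to stay near the limit, an estimated step that the limit leaves unreadable from compound 1 to compound 4. Compound 4 is estimated at 30000 nM, between 8000 nM and 100000 nM.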

Compound 4, inhibition constant: > 20000 nM
Compound 4: only a limit was reported; the forecaster's own chance of this, stated with the estimate: 85%; the middle value is on the limit's open side.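

For the compounds shown here, compound 4 also returns > 20000 nM as a limit and not a number, so no step between compound 1 and compound 4 can be read. Still open, as far as these compounds go, is whether in this assay any compound on this shared core gives a true number.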